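Lengthening the Sulfonyl Chain by One Carbon

A few compounds are considered here, and "the series" means these few. Any claim that something is new, unique, unknown or untested is made for them only; others in the source may bear on it.

Compound 1, `CC(C)NC(=O)CN1CCN(c2ccc(OCC3CCN(C(=O)OC(C)C)CC3)cn2)CC1`, in a functional assay on CHO-K1 cells for agonist activity at Glucose-dependent insulinotropic receptor (Homo sapiens), read by a luciferase reporter, with a stated time of 5 h (a lower number here means that less compound is needed, a higher number that more compound is needed for the effect), gives > 10000 nM; this is a limit of the assay, not a number.
Compound 2, `CC(C)OC(=O)N1CCC(COc2ccc(N3CCN(S(=O)(=O)C(C)C)CC3)nc2)CC1`, gives 300 nM.
Compound 3, `CCCS(=O)(=O)N1CCN(c2ccc(OCC3CCN(C(=O)OC(C)C)CC3)cn2)CC1`, gives 300 nM.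

Replacing the (isopropylcarbamoyl)methyl group of compound 1 with a sulfonyl group gave a large improvement: an at least 33-fold lower number from compound 1 to compound 2 (1.52 log units; beyond the scatter) and an at least 33-fold lower number from compound 1 to compound 3 (1.52 log units; beyond the scatter), both resting on (the limit of > 10000 nM in this assay, at which 1 of the 3 values shown sits). Between the two sulfonyl compounds, however, the shape of the alkyl group made no difference: no change at the digits printed from compound 2 to compound 3 (within the scatter). Compound 3 therefore stands level with compound 2, with nothing shown between them beyond the scatter.

Compound 4, `CCCCS(=O)(=O)N1CCN(c2ccc(OCC3CCN(C(=O)OC(C)C)CC3)cn2)CC1`, differs from compound 3 only in methyl in place of hydrogen on a saturated chain carbon, three bonds along the chain from a sulfonyl sulfur, so the chain grows from propyl to butyl. Within the data shown here, the one step that bears on this, from compound 2 to compound 3, changed nothing, so in this assay compound 4 is expected to give 300 nM, with a range from 120 nM to 750 nM, which means an expected step of no change at the digits printed from compound 3 to compound 4 (within the scatter).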

Compound 4, half-maximal effective concentration: 100 nM
The estimate for compound 4 lay 3.0-fold (0.48 log units) above the measured number; the whole stated range lies above it.
By their numbers in this assay, from the lowest: compound 4; then compounds 2 and 3 (each within the scatter of the next). At a limit, above all of these: compound 1.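

Here the alkyl group on the sulfonyl sulfur does make a difference, which compound 2 and compound 3 had not shown: one more carbon at the end of the chain, taking propyl to butyl, gives a 3.0-fold lower number from compound 3 to compound 4 (0.48 log units; beyond the scatter). The straight butyl chain also improves on the branched isopropyl group, with a 3.0-fold lower number from compound 2 to compound 4 (0.48 log units; beyond the scatter), so in this assay the sulfonyl group can be tuned through its alkyl chain and is not merely a replacement that works equally well with any small chain. The largest step, an at least 100-fold lower number from compound 1 to compound 4 (2.00 log units; beyond the scatter), rests on a limit of the assay for compound 1 and not on a number: the limit of > 10000 nM in this assay, at which 1 of the 4 values shown sits.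

The compounds shown leave open whether a longer chain, such as pentyl or hexyl, would lower the number further or lose the gain. They also leave open how a phenyl ring on the sulfonyl sulfur would compare with butyl.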